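From Dimethylcarbamoyl to Diisopropylcarbamoyl

The source may hold more compounds than are shown below. What is called first, only, known or untested is meant among the compounds shown, and "the series" means these compounds.

In a functional assay on MCF7 cells (Homo sapiens) for antiproliferative activity, read by MTT assay, with a stated time of 48 h (on this read-out lower numbers stand for stronger inhibition and higher numbers for weaker inhibition), compound 1 (`COC/C1=C/C[C@](C)(CCC=C(C)C)/C=C/[C@@H](OC(=O)C=C(C)C)[C@](C)(O)/C=C/C1=O`) gives 4130 nM and compound 2 (`CC(C)=CCC[C@]1(C)/C=C/[C@@H](OC(=O)C=C(C)C)[C@](C)(O)/C=C/C(=O)/C(C(=O)N(C)C)=C\C1`) gives 3670 nM. For the measured compounds named here, compound 2 therefore stands level with the only other measured compound, as the single measured step, a 1.1-fold lower number from compound 1 to compound 2 (0.05 log units; within the scatter), lies within the scatter. Compound 3 (`CC(C)=CCC[C@]1(C)/C=C/[C@@H](OC(=O)C=C(C)C)[C@](C)(O)/C=C/C(=O)/C(C(=O)N(C(C)C)C(C)C)=C\C1`) keeps the core of compound 2 and alters only the amine part of the amide: diisopropylamino in place of dimethylamino on a carbonyl carbon. The new diisopropylamino group sits on the same carbonyl carbon. The measured step bears on this change only indirectly, since it exchanges methoxymethyl for dimethylcarbamoyl and leaves the dimethylamino group untested. It offers no direction, so no step beyond the scatter is expected in this assay. The estimated shift, a 1.0-fold higher number from compound 2 to compound 3 (0.00 log units; within the scatter), is expected to remain small. Compound 3 is expected to give about 3700 nM, with an estimated range of 1600 nM to 8500 nM.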

Compound 3, half-maximal inhibitory concentration: 17200 nM
The estimate for compound 3 lay 4.6-fold (0.67 log units) below the measured number, outside the stated range (above it).
By their numbers in this assay, from the lowest: compounds 2 and 1 (each within the scatter of the next); then compound 3.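

In this assay the amine part of the amide on this carbonyl carbon turns out to matter: a 4.7-fold higher number from compound 2 to compound 3 (0.67 log units; beyond the scatter) comes with diisopropylamino in place of dimethylamino, whereas the earlier step stayed within the scatter. The exchange on the double-bonded ring carbon now also reads differently, with a 4.2-fold higher number from compound 1 to compound 3 (0.62 log units; beyond the scatter) for diisopropylcarbamoyl in place of methoxymethyl, so among these three compounds the outcome at this place depends on which amide is present and not merely on there being one. Nothing shown here accounts for this higher number.

The compounds shown leave open how diethylamino or a ring amine such as pyrrolidine on the same carbonyl carbon would read in this assay and whether either would stand with compound 2 or with compound 3. They also leave open where an amide keeping its hydrogen, such as isopropylamino, would fall.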